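The compounds below may be only part of what the source reports. "The series", "measured", "known", "first", "only" and "open" are said of these compounds alone.

Compound 1 `O=C(Cn1c(-c2ccccc2)cc(-c2ccccc2)c1-c1ccco1)Nc1nc2ccccc2s1` and compound 3 `CCc1nnc(NC(=O)Cn2c(-c3ccccc3)cc(-c3ccccc3)c2-c2ccccc2)s1` share no counted difference: how their cores differ is not broken down here. Compound 2 `CCc1nnc(NC(=O)Cn2c(-c3ccccc3)cc(-c3ccccc3)c2-c2ccco2)s1` stands between them, one change away from each. In an ADME assay on HEK-293T cells (Homo sapiens) for cytotoxicity, read by MTT assay, with a stated time of 72 h (a higher number here means a weaker inhibitor, a lower number a stronger inhibitor), compound 1 gives < 50000 nM, which is a limit of the assay and not a number. In this assay compound 2 gives < 50000 nM, likewise a limit. Compound 3 gives < 50000 nM in this assay, again a limit. The step from compound 1 to compound 2, 5-ethyl-1,3,4-thiadiazol-2-yl in place of 1,3-benzothiazol-2-yl on an amide-type nitrogen, reads as a step that the two limits leave unreadable from compound 1 to compound 2, and the step from compound 3 to compound 2 reads as a step that the two limits leave unreadable from compound 3 to compound 2; both are unreadable because of the limit of < 50000 nM in this assay, at which 3 of the 3 values shown sit.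

The change from compound 3 to compound 2 is furan-2-yl in place of phenyl on an aromatic carbon. Compound 4 `O=C(Cn1c(-c2ccccc2)cc(-c2ccco2)c1-c1ccco1)Nc1nc2ccccc2s1` is made from compound 1 by the same kind of change, (furan-2-yl in place of phenyl on an aromatic carbon), though not the same: in compound 2 the furan-2-yl enters next to the ring nitrogen and next to the ring atom that bears a ((5-ethyl-1,3,4-thiadiazol-2-yl)carbamoyl)methyl group, whereas in compound 4 it enters two ring bonds from the ring nitrogen and next to the ring atom that bears a furan-2-yl group.

Going by the values given here, for compound 4 the step in this assay is expected to be a step that the limit leaves unreadable from compound 1 to compound 4, because the only measured instance of this change sits on both sides at the limit (the limit of < 50000 nM in this assay, at which 3 of the 3 values shown sit). Compound 4 is estimated to give 30000 nM, expected between 8000 nM and 50000 nM.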

Compound 4, half-maximal inhibitory concentration: < 50000 nM
Compound 4 was reported as a limit (the forecaster's own chance of this, stated with the estimate: 80%); the middle value lies beyond the limit too.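

In this assay compound 4 gives < 50000 nM, which is a limit of the assay and not a number. The step from compound 1 to compound 4 cannot be read, because both compounds stand at that limit: the limit of < 50000 nM in this assay, at which 4 of the 4 values shown sit. The compounds shown leave open how far apart their true values lie, and whether furan-2-yl in place of phenyl alters the value at either place on the core.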